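The source may report more compounds than this note shows. Statements on the series, on what has been measured and on what is new or still open speak of the compounds shown alone.

Working notes on the series. The shared core of compound 1 `CCCCCN(C1=NCCN1)c1c(Br)cccc1Br` carries two other measured analogues, compound 2 `Brc1cccc(Br)c1N(CC1CCCCC1)C1=NCCN1` and compound 3 `Brc1cccc(Br)c1N(C1=NCCN1)C1CCCC1`, and one unmeasured member, compound 4 `Brc1cccc(Br)c1N(C1=NCCN1)C1CCCCC1`. In a physicochemical assay for acid dissociation, compound 1 gives 11; in the same assay compound 2 gives 11.2 and compound 3 gives 11.2. Compound 1 thus carries the smallest of the three numbers, but the gaps to the other two fall within the scatter, so no real ordering among them can be read.

The change from compound 1 to compound 4 is cyclohexyl in place of pentyl on a nitrogen on an aromatic ring. For the measured compounds named here, two measured steps bear on it, each replacing the pentyl of compound 1 with a ring-bearing group on the same nitrogen: a number 0.20 log units higher from compound 1 to compound 2 (within the scatter) and a number 0.20 log units higher from compound 1 to compound 3 (within the scatter). The further step no change at the digits printed from compound 2 to compound 3 (within the scatter) shows that exchanging one ring-bearing group for another leaves this assay likewise untouched. Every exchange of the group on this nitrogen seen so far stays within the scatter, and nothing in the data singles out cyclohexyl.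

Compound 4 is therefore expected to show a number 0.20 log units higher from compound 1 to compound 4 (within the scatter), nothing beyond the scatter. The estimate for compound 4 in this assay is 11.2, with a range of 10.8 to 11.6.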

Compound 4, acid dissociation constant: 11.3
Estimate against measurement, compound 4: 0.10 log units below; measured number inside the range.
By their numbers in this assay, from the lowest: compounds 1, 2, 3 and 4 (each within the scatter of the next).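

Working notes, continued. In this assay, cyclohexyl set directly on the nitrogen on an aromatic ring gives a number 0.30 log units higher from compound 1 to compound 4 (within the scatter), a number 0.10 log units higher from compound 3 to compound 4 (within the scatter) and a number 0.10 log units higher from compound 2 to compound 4 (within the scatter), so this group can be compared with each of the other three, and none of the comparisons goes beyond the scatter. The earlier compounds had not shown a six-membered non-aromatic ring of carbon only bound directly to this nitrogen; with it, the open pentyl chain, cyclopentyl, cyclohexylmethyl and cyclohexyl all remain indistinguishable at this position in this assay. No measurement is available that accounts for this flat result.

All four groups compared here are built of carbon only and carry no net charge, so the series says nothing about how the number would respond to an amine, a carboxylic acid or a hydroxyl-bearing chain on this nitrogen. Also open, on these data alone, is whether a much shorter chain such as methyl, or an aromatic ring such as phenyl, in place of pentyl would stay within the scatter as these four groups do.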